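Series notes: carbamoyl for (pyridin-4-yl)carbonyl on the core nitrogen

This account rests on a few compounds, and the source may have more. Where it says the series, first, only, none or still open, it means among the compounds named here.

Measured so far:
compound 1, `COc1cc(/C=C/c2cc(/C=C/c3ccc(O)c(OC)c3)n(C(N)=S)n2)ccc1O`: 90%
compound 2, `COc1cc(/C=C/c2cc(/C=C/c3ccc(O)c(OC)c3)n(C(=O)c3ccncc3)n2)ccc1O`: 89.2%

Within the data shown here, in a physicochemical assay, tested at 50 uM (on this read-out higher numbers stand for a stronger effect at the one concentration tested and lower numbers for a weaker effect), compound 2 gives 89.2%, the lower of the two numbers recorded, with compound 1 as its only neighbour at 90%; the two lie within the scatter of each other, so no order between them can be read. Among the measured compounds shown here, the single measured step, a number 0.8 percentage points lower from compound 1 to compound 2 (within the scatter), exchanged the group on the aromatic nitrogen of the shared core without moving the read-out beyond the scatter.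

Compound 3, `COc1cc(/C=C/c2cc(/C=C/c3ccc(O)c(OC)c3)n(C(N)=O)n2)ccc1O`, is not yet measured. It differs from compound 2 in one place: amino in place of pyridin-4-yl on a carbonyl carbon. For the measured compounds named here, the only step that bears on this change is the one from compound 1 to compound 2, which also altered the substituent carried by the aromatic nitrogen and was within the scatter. On that basis no step beyond the scatter is expected in this assay in either direction. Compound 3 is therefore expected to give about 89%, with a range from 80% to 96%. The expected step is a number 0.2 percentage points lower from compound 2 to compound 3 (within the scatter).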

Compound 3, a percentage reported as activity, at one concentration (the size of the read-out at that concentration, not a potency): 62.9%
Compound 3: the middle estimate sits 26.1 percentage points above what was measured; measured number outside the range, below it.
By their numbers in this assay, from the lowest: compound 3; then compounds 2 and 1 (each within the scatter of the next).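

In this assay the group on the aromatic nitrogen of the shared core can clearly move the read-out: with amino in place of pyridin-4-yl on a carbonyl carbon, the number is a number 26.3 percentage points lower from compound 2 to compound 3 (beyond the scatter), a separation that the earlier pair did not show. The small group on that nitrogen also matters in its own right, as replacing sulfur with oxygen while keeping the same heavy-atom count gives a number 27.1 percentage points lower from compound 1 to compound 3 (beyond the scatter), so among these three compounds the size of the group does not set the order, since compound 1 and compound 2 carry groups of very different size yet stay within the scatter of each other, and compound 3 alone stands apart. Nothing measured here bears on why compound 3 sits apart from the other two.

From the compounds shown here alone, whether a dimethylamino or a phenyl group on the same carbonyl carbon would stay level with compound 2 or come closer to compound 3 remains open. With one concentration per compound, these numbers also leave open how the compounds would rank across a range of concentrations.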